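The compounds below may be only part of what the source reports. "The series", "measured", "known", "first", "only" and "open" are said of these compounds alone.

Of the compounds shown here, three built on the same core have been tested in a functional assay on Jurkat cells (Homo sapiens); on this read-out higher numbers stand for weaker inhibition and lower numbers for stronger inhibition: compound 1 `CC(C)[C@H](NC(=O)COc1cccc2ccccc12)C(=O)N[C@@H](CC(=O)O)C(=O)COc1ccccc1C(F)(F)F`, compound 2 `CC(C)[C@H](NC(=O)COc1cccc2ccccc12)C(=O)N[C@@H](CC(=O)O)C(=O)COc1cccc(F)c1` and compound 3 `CC(C)[C@H](NC(=O)COc1cccc2ccccc12)C(=O)N[C@@H](CC(=O)O)C(=O)COc1cc(F)ccc1F`. They differ only in the ring group on an oxygen on a saturated carbon. Compound 1 gives > 100000 nM, which is a limit of the assay and not a number. Compound 2 gives > 100000 nM, also a limit. Compound 3 gives > 100000 nM, again a limit. Compound 3 therefore has no exact number of its own and shares its place with the other two, as the limit of > 100000 nM in this assay, at which 3 of the 3 values shown sit, shows.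

The next compound, compound 4 `CC(C)[C@H](NC(=O)COc1cccc2ccccc12)C(=O)N[C@@H](CC(=O)O)C(=O)COc1ccc(F)c(F)c1F`, puts 2,3,4-trifluorophenyl in place of 2,5-difluorophenyl on an oxygen on a saturated carbon. Among the measured compounds shown here, the closest precedent is a step that the two limits leave unreadable from compound 2 to compound 3, where fluoro replaces hydrogen on an aromatic carbon. Two further changes of this ring group are a step that the two limits leave unreadable from compound 1 to compound 2 and a step that the two limits leave unreadable from compound 1 to compound 3. None of the three steps has a size that can be read, and all three compounds end at the same limit. No step beyond the usual scatter, in either direction, is therefore expected in this assay, and a result reported only as a limit is likely. The expected change is a number no higher from compound 3 to compound 4 (the limit leaves the size open). The estimate for compound 4 is 100000 nM, with an expected range of 40000 nM to 200000 nM.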

Compound 4, half-maximal inhibitory concentration: 35800 nM
For compound 4 the middle estimate is 2.8-fold (0.45 log units) above the measured one; measured number outside the range, below it.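

Among the compounds shown here, this ring group, on an oxygen on a saturated carbon, can move the read-out in this assay: the change to 2,3,4-trifluorophenyl gives an at least 2.7-fold lower number from compound 3 to compound 4 (0.44 log units; beyond the scatter), the first step with a size that can be read even in part. The same ring also stands out against the other two, with an at least 2.7-fold lower number from compound 2 to compound 4 (0.44 log units; beyond the scatter) and with an at least 2.7-fold lower number from compound 1 to compound 4 (0.44 log units; beyond the scatter). These sizes are minimums and not exact measures, and the steps among compounds 1, 2 and 3 still cannot be read, because those three compounds sit together at one limit: the limit of > 100000 nM in this assay, at which 3 of the 4 values shown sit.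

The step from compound 3 to compound 4 adds a fluorine and also changes where the fluorines sit, so the compounds shown cannot separate the two changes; rings such as 2,3-difluorophenyl or 3,4-difluorophenyl on the same oxygen would bear on that question. Also open, on these data alone, is how an unsubstituted phenyl ring, or a ring carrying a methoxy group or a nitrile, would behave here, and whether a further fluorine, as in pentafluorophenyl, would bring the number lower still.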